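A few compounds are considered here, and "the series" means these few. Any claim that something is new, unique, unknown or untested is made for them only; others in the source may bear on it.

Of the compounds shown here, three built around a chromone-bearing sulfonamide have been tested in a functional assay on MCF7 cells (Homo sapiens) for cytotoxicity, read by sulforhodamine B assay, with a stated time of 72 h; on this read-out higher numbers stand for weaker inhibition and lower numbers for stronger inhibition. Compound 1 `O=C1/C(=C/c2coc3ccccc3c2=O)N=C(c2ccccc2)N1c1ccc(S(=O)(=O)Nc2nccs2)cc1` gives 88500 nM. Compound 3 `O=C1/C(=C/c2coc3ccccc3c2=O)N=C(c2ccccc2)N1c1ccc(S(=O)(=O)Nc2ncccn2)cc1` reaches only the assay limit, > 100000 nM, and no number is reported for it. The change from compound 3 to compound 1, (1,3-thiazol-2-yl in place of pyrimidin-2-yl on a sulfonamide nitrogen), produces an at least 1.1-fold lower number from compound 3 to compound 1 (0.05 log units; that floor lies within the scatter), a step that rests on the limit described by the limit of > 100000 nM in this assay, at which 2 of the 3 values shown sit.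

Compound 2 `O=c1c(CNc2ccc(S(=O)(=O)Nc3ncccn3)cc2)coc2ccccc12` shares the sulfonamide but carries a different core; how its core differs from that of compound 3 is not broken down here. In this assay compound 2 likewise returns only the assay limit, > 100000 nM, and no number.

Compound 4 `O=c1c(CNc2ccc(S(=O)(=O)Nc3nccs3)cc2)coc2ccccc12` remains unmeasured. It differs from compound 2 by 1,3-thiazol-2-yl in place of pyrimidin-2-yl on a sulfonamide nitrogen, the same change that separates compound 3 from compound 1. On that basis the step from compound 2 to compound 4 is expected to be a step that the limit leaves unreadable from compound 2 to compound 4, close to the step from compound 3 to compound 1, an at least 1.1-fold lower number from compound 3 to compound 1 (0.05 log units; that floor lies within the scatter). Compound 4 is therefore estimated at 120000 nM, between 50000 nM and 300000 nM, with a real chance that only a limit is reported.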

Compound 4, half-maximal inhibitory concentration: 58600 nM
Beside the measured number, compound 4's estimate is 2.0-fold (0.31 log units) above it; low and high end bracket the measured number.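

On the core of compound 2, 1,3-thiazol-2-yl in place of pyrimidin-2-yl on a sulfonamide nitrogen gives an at least 1.7-fold lower number from compound 2 to compound 4 (0.23 log units; that floor lies within the scatter) in this assay. Set beside the same change on the core of compound 1, the two steps point the same way, but each is only a floor, and they cannot be told apart: the same change on two cores in this assay, an at least 1.1-fold lower number (0.05 log units; that floor lies within the scatter) from compound 3 to compound 1 and an at least 1.7-fold lower number (0.23 log units; that floor lies within the scatter) from compound 2 to compound 4; the limit leaves it open whether they differ. The change therefore carries to a second core with no reversal showing, yet neither a matching size nor a step beyond the scatter is shown, since each step starts from a limit and not from a number: the limit of > 100000 nM in this assay, at which 2 of the 4 values shown sit.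

The compounds shown leave open how large either step really is, and so whether the two cores respond alike or differently to this change. They also leave open how the sulfonamide nitrogen would read on either core with another group on it, such as pyridin-2-yl or a plain methyl.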